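A few compounds are considered here, and "the series" means these few. Any claim that something is new, unique, unknown or untested is made for them only; others in the source may bear on it.

In a functional assay on MDA-MB-231 cells (Homo sapiens) for antiproliferative activity, read by MTT assay, with a stated time of 24 h (a higher number here means a weaker inhibitor, a lower number a stronger inhibitor), compound 2 (`Cc1ccc(C(=O)NNC(=O)c2ccc(NS(=O)(=O)c3cnc(O)nc3O)cc2)cc1`) gives > 20000 nM as its reading, which is a limit and not a number. Compound 1 (`O=C(NNc1ccccc1F)c1ccc(NS(=O)(=O)c2cnc(O)nc2O)cc1`), which carries 2-fluorophenyl, gives > 20000 nM as its reading, again a limit. Within the data shown here, the only measured step is a step that the two limits leave unreadable from compound 1 to compound 2 and it offers no size to build on, while the limit of > 20000 nM in this assay, at which 2 of the 2 values shown sit, is all the data hold. Compound 3 (`O=C(NNC(=O)c1ccccc1F)c1ccc(NS(=O)(=O)c2cnc(O)nc2O)cc1`) has 2-fluorophenyl in place of 4-methylphenyl on a carbonyl carbon. The estimated change in this assay is a step that the limit leaves unreadable from compound 2 to compound 3 and so nothing beyond the scatter is expected. For compound 3 the estimated value is 30000 nM within a range of 15000 nM to 60000 nM and another limit is likely.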

Compound 3, half-maximal inhibitory concentration: > 20000 nM
Compound 3 was reported as a limit (the forecaster's own chance of this, stated with the estimate: 90%); the middle value is on the limit's open side.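

In this assay compound 3 gives > 20000 nM, a limit, so the steps linking compound 1, compound 2 and compound 3 cannot be read. The compounds shown leave open whether any of these changes affects activity at all: the limit of > 20000 nM in this assay, at which 3 of the 3 values shown sit.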